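Swapping one ring on compound 3

The source may hold more compounds than are shown below. What is called first, only, known or untested is meant among the compounds shown, and "the series" means these compounds.

compound 1 `Cc1c(C(C)n2cnc3ncc(-c4cnc5ccccc5c4)nc32)ccc2ncccc12`: 450 nM
compound 2 `C1=C(c2cnc3ncn(Cc4ccc5ncccc5c4)c3n2)CCNC1`: 6660 nM
compound 3 `CC(NC/N=C/c1cnn(C)c1)c1ccc2ncccc2c1`: 197 nM

All three values come from a functional assay on NCI-H1993 cells (Homo sapiens) for inhibition, read by CCK-8 assay, with a stated time of 72 h; a higher number here means a weaker inhibitor, a lower number a stronger inhibitor. Compound 3 stands lowest at 197 nM, which makes it the strongest inhibitor of the three. Its distance to compound 1 at 450 nM lies beyond the scatter, and compound 2 at 6660 nM sits much further off.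

Compound 4 `CC(NC/N=C/c1ccncc1)c1ccc2ncccc2c1` keeps everything in compound 3 except one group: pyridin-4-yl in place of 1-methyl-1H-pyrazol-4-yl on a carbon with a double bond to nitrogen.

For the measured compounds named here, no measured pair here differs in a single place, so the data do not show directly what such a swap does. Going by the values given here, compound 3, at 197 nM, holds the best value so far, so a small rise in the number seems likelier than a fall, and the change may well stay within the scatter. The estimated change is a 1.5-fold higher number from compound 3 to compound 4 (0.18 log units; within the scatter). For compound 4 the estimated value is 300 nM, with an expected range from 80 nM to 1100 nM.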

Compound 4, half-maximal inhibitory concentration: 614 nM
Beside the measured number, compound 4's estimate is 2.0-fold (0.31 log units) below it; the range from low to high includes it.
By their numbers in this assay, from the lowest: compound 3; then compounds 1 and 4 (each within the scatter of the next); then compound 2.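

For the compounds shown here, compound 3 and compound 4 form the first measured pair that differs in one place: in this assay, pyridin-4-yl in place of 1-methyl-1H-pyrazol-4-yl on a carbon with a double bond to nitrogen gives a 3.1-fold higher number from compound 3 to compound 4 (0.49 log units; beyond the scatter) for this single change. The position is therefore sensitive to which aromatic ring it carries, even though both groups have 6 heavy atoms, and in this pair the five-membered ring gives the stronger inhibitor. Nothing measured here ties the difference to any particular feature of the two rings.

Open, as far as these compounds go, is how other groups at this place would compare with compound 3 at 197 nM, for example a plain phenyl ring or a pyrazole ring without its methyl group. A non-aromatic group, such as a simple amine, is also an open case.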